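Moving the thiophene attachment on compound 2

The source may report more compounds than this note shows. Statements on the series, on what has been measured and on what is new or still open speak of the compounds shown alone.

Among the measured compounds shown here, in a functional assay on ileum (Cavia porcellus) for inhibition (on this read-out lower numbers stand for stronger inhibition and higher numbers for weaker inhibition), compound 2 (`COC(=O)C1=C(C)NC(C)=C(C(=O)OC)C1c1c(-c2cccs2)nc2sccn12`) gives 110 nM, the lowest of three numbers so far. Compound 3 (`COC(=O)C1=C(C)NC(C)=C(C(=O)OC)C1c1c(-c2ccccn2)nc2sc(C)cn12`) gives 2810 nM, and compound 1 (`COC(=O)C1=C(C)NC(C)=C(C(=O)OC)C1c1c(-c2cccnc2)nc2sc(C)cn12`) gives 16000 nM.

Compound 4 (`COC(=O)C1=C(C)NC(C)=C(C(=O)OC)C1c1c(-c2ccsc2)nc2sccn12`) has the same atoms as compound 2, joined differently, with thiophen-3-yl in place of thiophen-2-yl on an aromatic carbon.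

For the measured compounds named here, only one measured step resembles this change, also swapping one attachment point of an aromatic ring for another: a 5.7-fold lower number from compound 1 to compound 3 (0.76 log units; beyond the scatter), with pyridin-2-yl in place of pyridin-3-yl. That step is modest but lies beyond the scatter. Going by the values given here, it involves a different ring, however, and no measured pair of thiophene isomers exists, so it suggests that such a swap can matter without showing a direction here.

The expected change is therefore small, at a 1.4-fold higher number from compound 2 to compound 4 (0.13 log units; within the scatter), an estimated step not beyond the scatter. For compound 4 the estimated value is 150 nM, with an expected range from 40 nM to 600 nM.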

Compound 4, half-maximal inhibitory concentration: 2.3 nM
Estimate against measurement, compound 4: 65-fold (1.81 log units) above, and the stated range ends above it.
By their numbers in this assay, from the lowest: compound 4; then compound 2; then compound 3; then compound 1.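

Moving the thiophene's point of attachment, with no atom added or lost, gives a 48-fold lower number from compound 2 to compound 4 (1.68 log units; beyond the scatter) in this assay and is a large step. This position, next to the ring nitrogen, therefore responds strongly not only to which ring it carries but also to how that ring is joined, and the step is larger than the modest 5.7-fold lower number from compound 1 to compound 3 (0.76 log units; beyond the scatter) seen between the two pyridines. No measurement available here accounts for the size of this difference.

Going by these compounds, it remains open whether thiophen-3-yl would give a similar gain on the core of compound 3, which carries a methyl that compound 4 lacks. On these data alone, the effect of a plain phenyl ring at this position, or of a chlorine on the thiophen-3-yl ring, also remains unknown.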